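Series notes: carbamate chain truncation toward compound 3

A few compounds are considered here, and "the series" means these few. Any claim that something is new, unique, unknown or untested is made for them only; others in the source may bear on it.

Compound 2 `COc1ccc(CCCOC(=O)N(c2ccccc2)C2CN3CCC2CC3)cc1F` is the weaker-looking of the two measured entries in an assay on CHO cells for displacement of a labelled ligand from muscarinic acetylcholine receptor M5 (Homo sapiens), read by scintillation counting, with a stated time of 2 h (a higher number here means a weaker inhibitor, a lower number a stronger inhibitor), giving 260 nM. For the measured compounds named here, its nearest neighbour is compound 1 `Cc1ccc(CCCOC(=O)N(c2ccccc2)C2CN3CCC2CC3)cc1F`, which gives 130 nM in this assay; the single recorded step, a 2.0-fold higher number from compound 1 to compound 2 (0.30 log units; within the scatter), stays within the scatter, so the two compounds cannot be ranked against each other.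

The step to compound 3 `O=C(OCCc1ccccc1)N(c1ccccc1)C1CN2CCC1CC2` is phenyl in place of 3-fluoro-4-methoxybenzyl on a saturated chain carbon, two bonds along the chain from an oxygen next to a carbonyl group. This removes both the substituted aromatic ring and the chain carbon that carried it, leaving a shorter link between the carbonyl oxygen and the aromatic ring.

Going by the values given here, no measured step bears directly on this change. Among the compounds with values here, the one available step, a 2.0-fold higher number from compound 1 to compound 2 (0.30 log units; within the scatter), only swaps a substituent on the aromatic ring and is small. Nothing in the series tests a shorter chain or a bare phenyl, so the expected step of a 1.9-fold higher number from compound 2 to compound 3 (0.28 log units; within the scatter) is uncertain in both size and direction; a loss of affinity is taken as somewhat more likely than a gain, but the range is kept wide. Compound 3 is therefore expected to give about 500 nM in this assay, within a range of 120 nM to 2500 nM.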

Compound 3, inhibition constant: 260 nM
Compound 3: middle estimate off by 1.9-fold (0.28 log units), on the high side; measured number inside the range.
By their numbers in this assay, from the lowest: compounds 1, 2 and 3 (each within the scatter of the next).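

In this assay, phenyl in place of 3-fluoro-4-methoxybenzyl on this saturated chain carbon gives no change at the digits printed from compound 2 to compound 3 (within the scatter) and phenyl in place of 3-fluoro-4-methylbenzyl at the same place gives a 2.0-fold higher number from compound 1 to compound 3 (0.30 log units; within the scatter) in the same read-out. The earlier pair varied only a substituent on the aromatic ring, whereas these steps replace the whole substituted benzyl group, with 10 heavy atoms leaving and 6 entering in the step from compound 2, and the assay resolves no difference, so neither the fluorine nor the methyl or methoxy group is shown to be required for a value in this range. Nothing available accounts for the three compounds reading alike.

These steps alter the ring substituents and the chain together, and their separate contributions remain unresolved, as does whether either one alone would move the number beyond the scatter. Also open, from the compounds shown here alone, is how the series responds to a longer chain carrying the bare phenyl, or to an amine or a carboxylic acid on the phenyl of compound 3.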